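The compounds below may be only part of what the source reports. "The series", "measured", "known", "first", "only" and "open" are said of these compounds alone.

Working notes on the series. Compound 1 `O=c1nc(N2CCN(NC3CCCCC3)CC2)sc2c([N+](=O)[O-])cc(C(F)(F)F)cc12` and compound 2 `O=c1nc(N2CCN(NCCC3CCCCC3)CC2)sc2c([N+](=O)[O-])cc(C(F)(F)F)cc12` share one core and differ only in the group on the amine nitrogen. In an ADME assay on Vero cells (Chlorocebus sabaeus) for cytotoxicity, read by MTT assay, with a stated time of 72 h (a higher number here means that more compound is tolerated, a lower number that less compound is tolerated), compound 1 gives only a limit, > 64 ug/mL. In this assay compound 2 likewise gives only a limit, > 64 ug/mL. Compound 2 thus stands at the limit of > 64 ug/mL in this assay, at which 2 of the 2 values shown sit, with no number of its own. The measured step that the two limits leave unreadable from compound 1 to compound 2 is the only one bearing on the next change, and its size cannot be read, since both ends are limits. Compound 3 `O=c1nc(N2CCN(Nc3ccc(OC(F)(F)F)cc3)CC2)sc2c([N+](=O)[O-])cc(C(F)(F)F)cc12` follows: 4-(trifluoromethoxy)phenyl in place of 2-cyclohexylethyl on an amine nitrogen. Going by the values given here, with one unreadable step as the sole guide, the step from compound 2 to compound 3 in this assay is expected to be a number no higher from compound 2 to compound 3 (the limit leaves the size open), without a readable direction. Compound 3 is estimated at 64 ug/mL in this assay, within 32 ug/mL to 128 ug/mL, and most likely to be reported again only as a limit.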

Compound 3, half-maximal cytotoxic concentration: > 64 ug/mL
Compound 3: no number, only a limit; the forecaster's own chance of this, stated with the estimate: 70%; the middle value lies on the limit itself.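

In this assay compound 3 gives only a limit, > 64 ug/mL. No new step can be read among compound 1, compound 2 and compound 3, since all their values are limits: the limit of > 64 ug/mL in this assay, at which 3 of the 3 values shown sit. The compounds shown leave open whether the group on the amine nitrogen changes tolerance at all.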